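Piperidin-1-yl Exchanged for 2,3-Dihydro-1H-indol-1-yl on the Shared Core

The compounds below may be only part of what the source reports. "The series", "measured", "known", "first", "only" and "open" are said of these compounds alone.

Two compounds built on one shared core have been measured in a functional assay on A549 cells (Homo sapiens) for inhibition, read by MTT assay, with a stated time of 72 h; a lower number here means a stronger inhibitor, a higher number a weaker inhibitor:

compound 1, `CN(c1ccc(Oc2ncnc3ccsc23)cc1)c1nccc(N2CCCC2)n1`, 6510 nM
compound 2, `CN(c1ccc(Oc2ncnc3ccsc23)cc1)c1nccc(N2CCCCC2)n1`, 8240 nM

Compound 2 stands at the highest of the two numbers in this assay; its nearest neighbour is compound 1, and the step of a 1.3-fold higher number from compound 1 to compound 2 (0.10 log units; within the scatter) lies within the scatter, so the two cannot be ordered against each other. The next step leads from compound 2 to compound 3, `CN(c1ccc(Oc2ncnc3ccsc23)cc1)c1nccc(N2CCc3ccccc32)n1`, and the change is 2,3-dihydro-1H-indol-1-yl in place of piperidin-1-yl on an aromatic carbon. Going by the values given here, only one measured step bears on this change, a 1.3-fold higher number from compound 1 to compound 2 (0.10 log units; within the scatter), which also altered the group on the same aromatic carbon and stayed within the scatter; it exchanged two non-aromatic rings, whereas the entering group brings one six-membered aromatic ring of carbon only, a change no measured pair covers. No more than a small step is therefore expected, a 1.2-fold lower number from compound 2 to compound 3 (0.07 log units; within the scatter), with wide bounds to allow for the untested part of the change. In this assay compound 3 is estimated at 7000 nM, within a range from 2500 nM to 20000 nM.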

Compound 3, half-maximal inhibitory concentration: 20500 nM
Compound 3: the middle estimate sits 2.9-fold (0.47 log units) below what was measured; measured number outside the range, above it.
By their numbers in this assay, from the lowest: compounds 1 and 2 (each within the scatter of the next); then compound 3.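

In this assay, the aromatic carbon next to the ring nitrogen now proves sensitive to the group it carries: exchanging the two non-aromatic rings had stayed within the scatter, whereas 2,3-dihydro-1H-indol-1-yl in place of piperidin-1-yl gives a 2.5-fold higher number from compound 2 to compound 3 (0.40 log units; beyond the scatter). The same holds when the entering group replaces pyrrolidin-1-yl, with a 3.1-fold higher number from compound 1 to compound 3 (0.50 log units; beyond the scatter), so among these three compounds compound 3 is the weakest inhibitor, and the one group bearing a six-membered aromatic ring of carbon only goes with a modest loss rather than a gain. Nothing measured here accounts for that loss.

The three compounds cannot separate the effect of the aromatic ring of carbon only from that of the additional atoms it brings, since no group of similar atom count without such a ring, such as azepan-1-yl, appears among them. From the compounds shown here alone, it also remains open how this position responds to groups of a different kind, such as morpholin-4-yl, an open-chain dimethylamino group or a primary amine.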